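Adding (methylsulfonyl)methyl to compound 3

The compounds below may be only part of what the source reports. "The series", "measured", "known", "first", "only" and "open" are said of these compounds alone.

Within the data shown here, in a physicochemical assay for lipophilicity (a lower number here means a more polar compound, a higher number a more lipophilic compound), compound 3 (`CCNC(=O)Nc1ccc(-c2nccc([C@@]34CCOC[C@@H]3C4)n2)cc1`) reads 3.9 on the numbers so far. Compound 1 (`CCNC(=O)Nc1ccc(-c2nc(CS(C)(=O)=O)cc([C@]34CCOC[C@H]3C4)n2)cc1`) reads 3.6 and stays within the scatter of compound 3. Compound 2 (`CNCC(=O)Nc1ccc(-c2nc(CS(C)(=O)=O)cc([C@@]34CCOC[C@@H]3C4)n2)cc1`) reads 3.1 and lies lower than compound 3 beyond the scatter.

Compound 4 (`CCNC(=O)Nc1ccc(-c2nc(CS(C)(=O)=O)cc([C@@]34CCOC[C@@H]3C4)n2)cc1`) comes from compound 3 through one change ((methylsulfonyl)methyl in place of hydrogen on an aromatic carbon) with (methylsulfonyl)methyl in place of hydrogen on an aromatic carbon. Among the measured compounds shown here, no measured pair shows this change alone. Compound 1 also carries (methylsulfonyl)methyl and its 3.6 reading points to a small downward step in this assay at about the edge of the scatter. The expected step is a number 0.30 log units lower from compound 3 to compound 4 (within the scatter) on this estimate. For compound 4 the estimated value is 3.6 with a range from 3.3 to 3.9 expected.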

Compound 4, partition coefficient: 3.6
Estimate against measurement, compound 4: no gap at the digits printed; low and high end bracket the measured number.
By their numbers in this assay, from the lowest: compound 2; then compounds 1, 4 and 3 (each within the scatter of the next).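

In this assay, (methylsulfonyl)methyl in place of hydrogen on this aromatic carbon gives a number 0.30 log units lower from compound 3 to compound 4 (within the scatter), so the change stays inside the scatter in a matched pair. Ethylamino in place of (methylamino)methyl on a carbonyl carbon gives a number 0.50 log units higher from compound 2 to compound 4 (beyond the scatter), the only step of the three beyond the scatter. Inverting both stereocentres gives no change at the digits printed from compound 1 to compound 4 (within the scatter), so configuration does not register in this assay for this pair: the fact that compounds 1 and 4 differ only in the configuration as drawn

Open, from the compounds shown here alone, is whether an amine or a carboxylic acid at the same aromatic carbon would give a step beyond the scatter.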